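Exchanging 4-methoxyphenyl for (4-chlorophenyl)amino on the shared core

A few compounds are considered here, and "the series" means these few. Any claim that something is new, unique, unknown or untested is made for them only; others in the source may bear on it.

Three compounds share one core: compound 1 (`COc1cc(C(=O)c2sc3ccccc3c2-c2ccc(C)cc2)cc(OC)c1OC`), compound 2 (`COc1ccc(-c2c(C(=O)c3cc(OC)c(OC)c(OC)c3)sc3ccccc23)cc1`) and compound 3 (`COc1cc(C(=O)c2sc3ccccc3c2-c2ccc(SC)cc2)cc(OC)c1OC`). In a functional assay on K562 cells (Homo sapiens) for antiproliferative activity, read by MTT assay, with a stated time of 72 h (on this read-out higher numbers stand for weaker inhibition and lower numbers for stronger inhibition), compound 1 gives 3500 nM while compound 2 gives 1700 nM and compound 3 gives 1800 nM in the same test. Compound 2 thus stands within the scatter of compound 3 and apart from compound 1 by a margin just beyond it (a 2.1-fold lower number from compound 1 to compound 2 (0.31 log units; beyond the scatter)). The other two steps (a 1.9-fold lower number from compound 1 to compound 3 (0.29 log units; within the scatter)) and (a 1.1-fold higher number from compound 2 to compound 3 (0.02 log units; within the scatter)) stay within the scatter.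

The next compound is compound 4 (`COc1cc(C(=O)c2sc3ccccc3c2Nc2ccc(Cl)cc2)cc(OC)c1OC`), in which (4-chlorophenyl)amino stands in place of 4-methoxyphenyl on an aromatic carbon of a five-membered aromatic ring with 1 sulfur ((4-chlorophenyl)amino in place of 4-methoxyphenyl on an aromatic carbon). The measured steps bear on this change only loosely. They exchange methyl, methoxy and methylsulfanyl on an aromatic carbon, and none tests an amino link or a chlorine. The only one beyond the scatter is modest, so the data offer no direction for the new group. No step beyond the scatter is therefore expected in this assay for this exchange, although confidence is low. The estimated step is a 1.1-fold lower number from compound 2 to compound 4 (0.05 log units; within the scatter) with a wide margin on either side. Compound 4 is estimated at 1500 nM with an expected range from 250 nM to 6000 nM in this test.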

Compound 4, half-maximal inhibitory concentration: 1100 nM
Estimate against measurement, compound 4: 1.4-fold (0.13 log units) above; the measured number falls inside the stated range.
By their numbers in this assay, from the lowest: compounds 4, 2, 3 and 1 (each within the scatter of the next, the first and the last beyond it).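

In this assay, the aromatic carbon of the five-membered aromatic ring with 1 sulfur accepts a nitrogen-linked aryl group carrying a hydrogen-bond donor without leaving the scatter of the directly linked aryl compounds: the exchange for 4-methoxyphenyl gives a 1.5-fold lower number from compound 2 to compound 4 (0.19 log units; within the scatter), and the exchange for 4-(methylsulfanyl)phenyl gives a 1.6-fold lower number from compound 3 to compound 4 (0.21 log units; within the scatter). Only the exchange for 4-methylphenyl stands beyond the scatter, and modestly so, with a 3.2-fold lower number from compound 1 to compound 4 (0.50 log units; beyond the scatter), so these compounds show that the position has room for this different link but do not show a clear gain over compound 2 or compound 3. No measurement at hand accounts for these steps.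

The exchange alters the link and the group on the outer ring together, so the compounds shown leave open what the amino link and the chlorine each contribute, a question that 4-chlorophenyl or (4-methoxyphenyl)amino at the same carbon would address. They also leave open how this position would respond to a longer chain, such as benzylamino, or to an oxygen link, such as 4-chlorophenoxy.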